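Phenyl ester anilides: permeability after swapping the amide aryl group

The compounds below may be only part of what the source reports. "The series", "measured", "known", "first", "only" and "open" are said of these compounds alone.

Measured compounds:
compound 1 `CN1CCN(c2ccc(C(=O)Oc3ccccc3)cc2NC(=O)c2ccc(F)c([N+](=O)[O-])c2)CC1` — 60 10^-6 cm/s
compound 2 `COC(=O)c1ccc(N2CCN(C)CC2)c(NC(=O)c2ccc(F)c([N+](=O)[O-])c2)c1` — 52.4 10^-6 cm/s

In an ADME assay for permeability, using PAMPA, with a stated time of 4 h (on this read-out higher numbers stand for higher permeability and lower numbers for lower permeability), compound 1 gives 60 10^-6 cm/s, the highest of the two numbers measured, with compound 2 nearest at 52.4 10^-6 cm/s. Among the compounds with values here, the only measured step, a 1.1-fold lower number from compound 1 to compound 2 (0.06 log units; within the scatter), comes from a methyl in place of a phenyl on an oxygen next to a carbonyl group and lies within the scatter.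

Compound 3 `Cc1c(F)ccc(C(=O)Nc2cc(C(=O)Oc3ccccc3)ccc2N2CCN(C)CC2)c1Cl` has not yet been measured. It differs from compound 1 by 2-chloro-4-fluoro-3-methylphenyl in place of 4-fluoro-3-nitrophenyl on a carbonyl carbon, a 2-chloro-4-fluoro-3-methylphenyl in place of a 4-fluoro-3-nitrophenyl on a carbonyl carbon. Within the data shown here, no measured step touches this part of the molecule; the step from compound 1 to compound 2 concerns the ester and gives no guide beyond showing that compounds sit close together in this assay. On that basis, the step of a 1.2-fold higher number from compound 1 to compound 3 (0.07 log units; within the scatter) is expected to stay within the scatter. Compound 3 is therefore estimated to give 70 10^-6 cm/s, with a range from 35 10^-6 cm/s to 140 10^-6 cm/s.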

Compound 3, apparent permeability: 48 10^-6 cm/s
Estimate against measurement, compound 3: 1.5-fold (0.16 log units) above; low and high end bracket the measured number.
By their numbers in this assay, from the lowest: compounds 3, 2 and 1 (each within the scatter of the next).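

In this assay, putting 2-chloro-4-fluoro-3-methylphenyl in place of 4-fluoro-3-nitrophenyl on a carbonyl carbon whose other neighbour is an amide-type nitrogen gives a 1.3-fold lower number from compound 1 to compound 3 (0.10 log units; within the scatter). Within the data shown here, this is the only measured change at this position, and it shows that a full exchange of the aryl group, from one with 2 hydrogen-bond acceptors to one with 0 and with chlorine and methyl entering as the nitro group leaves, still keeps compound 3 within the scatter of compound 1, as the change at the ester kept compound 2. No measured evidence on any property of these groups bears on this result.

The compounds shown leave open whether the 2-chloro-4-fluoro-3-methylphenyl group would read the same way on the methyl ester of compound 2, since no compound here combines the two changes. They also leave open how this assay would read for an aryl group on that carbonyl carbon that carries a carboxylic acid or a primary amine.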